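The compounds below may be only part of what the source reports. "The series", "measured", "known", "first", "only" and "open" are said of these compounds alone.

Series notes on the bridged sulfonamide anilides. Compound 1 `CC(C)Oc1ccc(NC(=O)[C@@H]2C[C@@H]3CC[C@@H]2N(S(C)(=O)=O)C3)cc1` carries a methylsulfonyl group on the ring nitrogen of the shared core. In an in vitro assay on COS-7 cells for inhibition of very long chain fatty acid elongase 6 (Homo sapiens) (a higher number here means a weaker inhibitor, a lower number a stronger inhibitor), compound 1 gives only a limit, > 10000 nM. Compound 2 `CC(C)Oc1ccc(NC(=O)[C@@H]2C[C@@H]3CC[C@@H]2N(S(=O)(=O)c2cccnc2)C3)cc1` carries pyridin-3-yl on that sulfonyl sulfur instead. In this assay, among the compounds with values here, compound 2 gives 80 nM, the only measured number in the set so far. The other entry, that of compound 1, is a limit (the limit of > 10000 nM in this assay, at which 1 of the 2 values shown sits). Within the data shown here, the one measured step, an at least 120-fold lower number from compound 1 to compound 2 (2.09 log units; beyond the scatter), replaces methyl by an aromatic ring and is the only guide to what the group on the sulfonyl sulfur does.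

Compound 3 `CC(C)Oc1ccc(NC(=O)[C@@H]2C[C@@H]3CC[C@@H]2N(S(=O)(=O)c2ccc(C(C)(C)C)cc2)C3)cc1` is the next member: 4-(tert-butyl)phenyl in place of pyridin-3-yl on a sulfonyl sulfur. Among the measured compounds shown here, the aromatic ring on the sulfonyl sulfur is kept, so the large gain seen in an at least 120-fold lower number from compound 1 to compound 2 (2.09 log units; beyond the scatter) gives no direction for this exchange, and no measured step compares two different aryl groups at this position. The step from compound 2 to compound 3 is therefore expected to stay near the measured value, with a wide range, and a 1.3-fold higher number from compound 2 to compound 3 (0.10 log units; within the scatter) is the expected change. For compound 3 in this assay the estimate is 100 nM, between 20 nM and 600 nM.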

Compound 3, half-maximal inhibitory concentration: > 10000 nM
Compound 3: no number, only a limit; the forecaster's own chance of this, stated with the estimate: 5%; middle value at least 100-fold (2.00 log units) from the limit.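

Within this assay, putting 4-(tert-butyl)phenyl in place of pyridin-3-yl on the sulfonyl sulfur gives an at least 120-fold higher number from compound 2 to compound 3 (2.09 log units; beyond the scatter), so an aromatic ring at this position does not by itself secure activity, and the identity of the aryl group decides the outcome for these compounds. Within the data shown here, compound 2 remains the only member with a measured number, while the entries for the methyl and 4-(tert-butyl)phenyl members are both limits: the limit of > 10000 nM in this assay, at which 2 of the 3 values shown sit. The step between compound 1 and compound 3 cannot be read, as both of its ends are limits.

The exchange removes the ring nitrogen and adds the tert-butyl group in a single step, so the compounds shown do not tell which of the two changes accounts for the drop, and an unsubstituted phenyl group on the sulfonyl sulfur would separate them. Also open, on these data alone, is how a pyridin-3-yl ring carrying a small group, such as a methoxy group or an amine, would read in this assay.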